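A few compounds are considered here, and "the series" means these few. Any claim that something is new, unique, unknown or untested is made for them only; others in the source may bear on it.

Compound 1 `Cc1c(OCCCCOc2ccccc2C(=O)O)ccc(C(=O)CC(C)C)c1O` gives 92.4% in an assay on HEK293 cells for positive allosteric modulation of metabotropic glutamate receptor 2 (Rattus norvegicus), read by thallium flux, with a stated time of 2.5 min (on this read-out higher numbers stand for larger maximal responses and lower numbers for smaller maximal responses), the second highest of the three numbers. Compound 2 `Cc1c(OCCCCOc2ccccc2C(=O)O)ccc(C(=O)CC2CCCC2)c1O` gives 98.8%, and a number 6.4 percentage points higher from compound 1 to compound 2 (within the scatter), so the two show no difference of note. Compound 3 `COc1ccc(C(=O)O)cc1OCCCCOc1ccc(C(=O)C(C)C)c(O)c1C`, which carries its carboxylic acid on a differently substituted ring, gives 66.6%, a number well under that of compound 1.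

Compound 4 `Cc1c(OCCCCOc2ccc(C(=O)O)cc2Cl)ccc(C(=O)CC(C)C)c1O` differs from compound 1 at the aryl ether end: 4-carboxy-2-chlorophenyl in place of 2-carboxyphenyl on an oxygen on a saturated carbon. Among the compounds with values here, no measured step changes the aryl group in this way, so only the lower number of compound 3 offers any hint. Compound 4 is therefore expected to give a maximal response somewhat under that of compound 1, with a number 14.4 percentage points lower from compound 1 to compound 4 (beyond the scatter) as the estimated step.

Compound 4 is estimated at 78%, in the range 55% to 100%.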

Compound 4, largest response reached (reported as percent of maximum), in percent of the reference or control that the assay uses: 99.5%
Compound 4: the middle estimate sits 21.5 percentage points below what was measured, within the range that was stated.
By their numbers in this assay, from the lowest: compound 3; then compounds 1, 2 and 4 (each within the scatter of the next).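

In this assay, the aryl group on this ether oxygen can be exchanged without loss of maximal response: 4-carboxy-2-chlorophenyl in place of 2-carboxyphenyl gives a number 7.1 percentage points higher from compound 1 to compound 4 (within the scatter). Within the data shown here, this is the first step at this end of the molecule, and it shows that the two differently substituted carboxyphenyl groups are not told apart by this read-out. Nothing available explains this result. On these data alone, the chlorine and the new placement of the carboxylic acid enter together, so their separate contributions remain open. As far as these compounds go, it also remains open how a tetrazole in place of the carboxylic acid, or a bromine in place of the chlorine, would read.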